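The source may hold more compounds than are shown below. What is called first, only, known or untested is meant among the compounds shown, and "the series" means these compounds.

Measured in an ADME assay on the whole organism (strain 129/SvEvBrd x C57BL/6) for metabolic stability, with Mus musculus as the target; a lower number here means that the compound disappears faster, a higher number that the compound lasts longer:
- compound 1 `CC(=O)c1cccc([C@@H](O)[C@H](O)[C@H](O)CO)n1`: 2.1 h
- compound 2 `CC(=O)c1nc([C@@H](O)[C@H](O)[C@H](O)CO)c(C)[nH]1`: 6.2 h
- compound 3 `Cc1nc(-c2nc([C@@H](O)[C@H](O)[C@H](O)CO)c[nH]2)cs1`: 2.1 h

Compound 3 is level with compound 1 within the scatter, and the two share the lowest number of the three. Compound 2 stands higher, beyond the scatter.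

The next compound to be read in this assay is compound 4 `OC[C@@H](O)[C@@H](O)[C@H](O)c1c[nH]c(-c2ncon2)n1`. It carries 1,2,4-oxadiazol-3-yl in place of 2-methyl-1,3-thiazol-4-yl on an aromatic carbon of a five-membered aromatic ring with 2 nitrogen, between two ring nitrogen atoms (1,2,4-oxadiazol-3-yl in place of 2-methyl-1,3-thiazol-4-yl on an aromatic carbon).

Among the compounds with values here, no two measured compounds differ in one place alone, so no measured step shows what this exchange does. The expectation therefore starts from compound 3 at 2.1 h, and its upper end stays close to compound 2 at 6.2 h. The expected change is a 1.2-fold higher number from compound 3 to compound 4 (0.08 log units; within the scatter), which is not expected to exceed the scatter. The estimate for compound 4 is 2.5 h, with an expected range of 1.2 h to 5.5 h.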

Compound 4, half-life: 0.7 h
Estimate against measurement, compound 4: 3.6-fold (0.55 log units) above; measured number outside the range, below it.
By their numbers in this assay, from the lowest: compound 4; then compounds 1 and 3 (each within the scatter of the next); then compound 2.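

In this assay, within the data shown here, the exchange of 2-methyl-1,3-thiazol-4-yl for 1,2,4-oxadiazol-3-yl gives a 3.0-fold lower number from compound 3 to compound 4 (0.48 log units; beyond the scatter), the first single-place step. It shows that the half-life responds to the group on this aromatic carbon between two ring nitrogen atoms, even when one five-membered aromatic ring replaces another and neither brings a hydrogen-bond donor or a net charge. Nothing available explains this step.

With a single pair, the roles of the lost methyl, the lost sulfur and the added ring hetero atom cannot be separated. Also open, from the compounds shown here alone, is how a simple methyl, an amine, a carboxylic acid or a longer chain at this place would read in this assay, and whether the step carries over to other cores.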